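A few compounds are considered here, and "the series" means these few. Any claim that something is new, unique, unknown or untested is made for them only; others in the source may bear on it.

Measured in an ADME assay on HEK293 cells (Homo sapiens) for cytotoxicity; on this read-out higher numbers stand for weaker inhibition and lower numbers for stronger inhibition:
- compound 1 `O=C(N[C@H]1CN(C(=O)C2CC2)C[C@H]1NC(=O)c1ccc(Cl)s1)c1ccc(-n2ccccc2=O)cc1`: > 100000 nM
- compound 2 `O=C(N[C@H]1CN(C(=O)c2ccccc2)C[C@H]1NC(=O)c1ccc(Cl)s1)c1ccc(-n2ccccc2=O)cc1`: > 100000 nM
- compound 3 `COCCOC(=O)N1C[C@H](NC(=O)c2ccc(-n3ccccc3=O)cc2)[C@H](NC(=O)c2ccc(Cl)s2)C1`: > 100000 nM

For the measured compounds named here, all three values are limits of the assay and not numbers, and the series so far sits entirely at one point: the limit of > 100000 nM in this assay, at which 3 of the 3 values shown sit. Compound 3 therefore has only a limit, > 100000 nM, with no number to serve as a starting point.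

The next compound is compound 4 `CC(C)S(=O)(=O)N1C[C@H](NC(=O)c2ccc(-n3ccccc3=O)cc2)[C@H](NC(=O)c2ccc(Cl)s2)C1`, which carries isopropylsulfonyl in place of (2-methoxyethoxy)carbonyl on an amine nitrogen in a ring.

Going by the values given here, three measured steps bear on this change, as each swaps the group on a carbonyl carbon: a step that the two limits leave unreadable from compound 1 to compound 2, a step that the two limits leave unreadable from compound 1 to compound 3 and a step that the two limits leave unreadable from compound 2 to compound 3. None of them has a readable size. On these data alone, the closest of them end at or start from compound 3, but none replaces the carbonyl with a sulfonyl, so the change itself is untested.

No step beyond the scatter is expected in this assay, and no direction is expected either. The estimated step is a number no higher from compound 3 to compound 4 (the limit leaves the size open). Most likely the result will again be reported only as a limit. The estimate for compound 4 is 100000 nM, with an expected range from 40000 nM to 200000 nM.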

Compound 4, half-maximal inhibitory concentration: > 100000 nM
Compound 4 ended at the assay's limit; the forecaster's own chance of this, stated with the estimate: 85%; the middle value lies on the limit itself.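

In this assay compound 4 gives > 100000 nM as a limit of the assay and not a number. Its steps from compound 1, compound 2 and compound 3 therefore cannot be read. The compounds shown leave open whether any group on the ring nitrogen changes this read-out, with the series still at a single point: the limit of > 100000 nM in this assay, at which 4 of the 4 values shown sit.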